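The compounds below may be only part of what the source reports. "The series", "measured", "known", "first", "only" and "open" are said of these compounds alone.

Measured so far in a functional assay on PC-3 cells (Homo sapiens) for antiproliferative activity, read by sulforhodamine B assay, with a stated time of 48 h; on this read-out lower numbers stand for stronger inhibition and higher numbers for weaker inhibition:

compound 1, `COc1ccc(C(=O)Oc2cc3c(cc2C)[C@@H](C(C)C)CC=C3C)cc1`: 32200 nM
compound 2, `Cc1cc2c(C(C)C)ccc(C)c2cc1OC(=O)c1ccc(C(F)(F)F)cc1`: 34000 nM

Both esters of the shared core sit in the same weak region of this assay . Compound 2 has the higher of the two numbers, but its nearest neighbour, compound 1, lies within the scatter of it, so the two are not separated and no ordering between them can be drawn from these two values.

Compound 3, `Cc1cc2c(C(C)C)ccc(C)c2cc1OC(=O)c1ccc([N+](=O)[O-])cc1`, is the next member to be measured. It differs from compound 2 by nitro in place of trifluoromethyl on an aromatic carbon. Among the measured compounds shown here, no pair of already measured compounds carries this exchange, so there is no measured step to lean on; the only guidance is that the one substituent exchange seen so far on this aromatic carbon, between compound 1 and compound 2, left the read-out inside the scatter.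

On that basis, the step from compound 2 to compound 3 is expected to stay within the scatter, a 1.1-fold lower number from compound 2 to compound 3 (0.05 log units; within the scatter), with no clear direction. Compound 3 is accordingly estimated at 30000 nM, within a range from 12000 nM to 80000 nM.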

Compound 3, half-maximal inhibitory concentration: 17600 nM
Estimate against measurement, compound 3: 1.7-fold (0.23 log units) above; low and high end bracket the measured number.
By their numbers in this assay, from the lowest: compounds 3, 1 and 2 (each within the scatter of the next).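

In this assay, the exchange of trifluoromethyl for nitro on this aromatic carbon, para to a large group, gives a 1.9-fold lower number from compound 2 to compound 3 (0.29 log units; within the scatter). Among the compounds shown here, this is the first measured step at this position between two compounds that differ in one place only, and it shows that the read-out stays within the scatter when the entering group differs in its atoms and brings 2 hydrogen-bond acceptors where the leaving group has 0, so the two groups are not separated here and no ranking of them can be drawn from this pair. No measurement is available that bears on what underlies this small step.

From the compounds shown here alone, whether an amine or a carboxylic acid on this same aromatic carbon would move the number beyond the scatter remains open, since the two groups compared so far give no trend that could be extended to other substituents. Going by these compounds, it is also open whether an amide in place of the ester linkage shared by compound 2 and compound 3 would shift the read-out in this assay out of this weak region.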